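The compounds below may be only part of what the source reports. "The series", "measured", "known", "first", "only" and "open" are said of these compounds alone.

Values measured in a functional assay on NCI-H520 cells (Homo sapiens) (a lower number here means a stronger inhibitor of growth, a higher number a weaker inhibitor of growth), are these
- compound 1 `O=S(=O)(/C=C/c1ccc(F)cc1)Cc1ccc(Nc2ncnc3ccccc23)cc1` gives 13000 nM
- compound 2 `O=S(=O)(/C=C/c1ccc(Cl)c(Cl)c1)Cc1ccc(Nc2ncnc3ccccc23)cc1` gives 32000 nM
- compound 3 `O=S(=O)(/C=C/c1ccc(Cl)cc1Cl)Cc1ccc(Nc2ncnc3ccccc23)cc1` gives 12000 nM

Compound 3 shares the low end of these values with compound 1, the two lying within the scatter of each other, while compound 2 stands apart (a 2.7-fold lower number from compound 2 to compound 3 (0.43 log units; beyond the scatter)). Compound 4 `O=S(=O)(/C=C/c1ccc(F)cc1Cl)Cc1ccc(Nc2ncnc3ccccc23)cc1` differs from compound 3 in one group, with fluoro in place of chloro on an aromatic carbon, para to a large group (fluoro in place of chloro on an aromatic carbon). It keeps the chloro group of compound 3 and carries the fluoro group of compound 1. The nearest evidence is therefore the step between those two neighbours (a 1.1-fold lower number from compound 1 to compound 3 (0.03 log units; within the scatter)), which lies within the scatter. Another step (a 2.5-fold higher number from compound 1 to compound 2 (0.39 log units; beyond the scatter)) shows that a different halogen pattern on this ring can move the number modestly, so the range stays wide. In this assay, the expected result is a 1.0-fold higher number from compound 3 to compound 4 (0.02 log units; within the scatter) and no change beyond the scatter. Compound 4 is estimated at 12500 nM with an expected range from 6000 nM to 25000 nM in this measurement.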

Compound 4, concentration for 50% growth inhibition: 100000 nM
For compound 4 the middle estimate is 8.0-fold (0.90 log units) below the measured one; the measured number lies above the stated range.
By their numbers in this assay, from the lowest: compounds 3 and 1 (each within the scatter of the next); then compound 2; then compound 4.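

In this assay, fluoro in place of chloro on this aromatic carbon, para to a large group, is not a neutral swap (an 8.3-fold higher number from compound 3 to compound 4 (0.92 log units; beyond the scatter)), and compound 4 is the weakest inhibitor of growth of the four. Adding chloro to compound 1 also raises the number (a 7.7-fold higher number from compound 1 to compound 4 (0.89 log units; beyond the scatter)), so the two halogens do not act independently: the ring that carries both chloro and fluoro behaves differently from the rings of compound 1 and compound 3. Compound 4 even lies beyond compound 2 (a 3.1-fold higher number from compound 2 to compound 4 (0.49 log units; beyond the scatter)), which had marked the weak end of the series.

Still open, as far as these compounds go, is how a methoxy group or an amine at this carbon would behave, with the chloro group kept in place. Whether such a ring would resemble compound 3 or compound 4 cannot be told from these compounds. No measurement here explains why this halogen pairing weakens growth inhibition.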